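Swapping the Sulfur Substituent of Compound 1

A few compounds are considered here, and "the series" means these few. Any claim that something is new, unique, unknown or untested is made for them only; others in the source may bear on it.

Three compounds have been measured in a functional assay on DU-145 cells (Homo sapiens) for inhibition, read by trypan blue exclusion, with a stated time of 96 h; on this read-out lower numbers stand for stronger inhibition of growth and higher numbers for weaker inhibition of growth:

Compound 1 `COc1ccccc1/C=C(/SCc1ccc(Cl)c(Cl)c1)C(=O)c1ccc(Cl)cc1`: 10000 nM
Compound 2 `O=C(/C(=C\c1ccccc1OCc1ccccc1)SCc1ccc(Cl)c(Cl)c1)c1ccc(Cl)cc1`: 10000 nM
Compound 3 `O=C(/C(=C\c1ccc(Br)cc1)S(=O)(=O)c1ccc(Br)cc1)c1ccc(Br)cc1`: 10000 nM

Compound 1 stands level with compound 2 and compound 3 at the digits shown; its nearest neighbour is compound 2 and its furthest is compound 3, yet all three agree within the scatter. Going by the values given here, the one step that joins two measured compounds, phenyl in place of hydrogen on a saturated chain carbon bound to an oxygen on an aromatic ring, gives no change at the digits printed from compound 1 to compound 2 (within the scatter).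

Compound 4 `COc1ccccc1/C=C(/Sc1ccc(C)cc1)C(=O)c1ccc(Cl)cc1` is the compound not yet measured. It differs from compound 1 by 4-methylphenyl in place of 3,4-dichlorobenzyl on a sulfur. Among the compounds with values here, no measured pair changes the group on that sulfur, so no step bears directly on this change; the only step available, from compound 1 to compound 2, concerns another part of the molecule and was flat. Compound 3 carries a different arrangement at the sulfur altogether and sits at the same level as compound 1. Within the data shown here, the series so far shows no movement in this assay at all, and nothing in it points toward stronger or weaker growth inhibition for compound 4. The expected step from compound 1 to compound 4 is therefore no change at the digits printed from compound 1 to compound 4 (within the scatter), none beyond the scatter. Compound 4 is estimated at 10000 nM, with a range from 4000 nM to 25000 nM.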

Compound 4, concentration for 50% growth inhibition: 25000 nM
Compound 4: the middle estimate sits 2.5-fold (0.40 log units) below what was measured; the range from low to high includes it.
By their numbers in this assay, from the lowest: compounds 1, 2 and 3 (each within the scatter of the next); then compound 4.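

In this assay, going by these compounds alone, the group on the sulfur is the first place where a single change moves the number beyond the scatter: 4-methylphenyl in place of 3,4-dichlorobenzyl gives a 2.5-fold higher number from compound 1 to compound 4 (0.40 log units; beyond the scatter). The step is modest and runs toward weaker inhibition of growth, but it shows that this position is not as silent as the part of the molecule changed in the flat step no change at the digits printed from compound 1 to compound 2 (within the scatter). Since 3,4-dichlorobenzyl and 4-methylphenyl differ in more than one feature, including the presence of chlorine, this single step cannot show which feature matters. Nothing available offers an explanation for the step.

The compounds shown leave open whether a plain benzyl or a 4-chlorophenyl group on the sulfur would stay level with compound 1 or fall in with compound 4, a comparison that would separate the chlorine atoms from the rest of the swap. Compound 1 gives 10000 nM; the compounds shown also leave open whether a group carrying an amine or a carboxylic acid at this sulfur would give a lower number.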